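The source may report more compounds than this note shows. Statements on the series, on what has been measured and on what is new or still open speak of the compounds shown alone.

Working notes on the series. In a functional assay on K562 cells (Homo sapiens) for cytotoxicity, read by sulforhodamine B assay (a lower number here means a stronger inhibitor of growth, a higher number a weaker inhibitor of growth), compound 1 (`CC1=CC[C@@H]([C@@](C)(O)CCCC(C)(C)NC(=S)N/N=C\c2ccccc2)CC1`) gives 20900 nM and compound 2 (`CC1=CC[C@@H]([C@@](C)(O)CCCC(C)(C)NC(=S)N/N=C\c2ccc(N(C)C)cc2)CC1`) gives 42000 nM. These two numbers lie within the scatter of each other, so compound 2 cannot be separated from compound 1 on the data so far.

The next compound is compound 3 (`CC1=CC[C@@H]([C@@](C)(O)CCCC(C)(C)NC(=S)N/N=C\c2cccc([N+](=O)[O-])c2)CC1`), still unmeasured. The change from compound 2 is 3-nitrophenyl in place of 4-(dimethylamino)phenyl on a carbon with a double bond to nitrogen. The rest of the structure stays the same.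

Going by the values given here, only one measured step bears on this change: a 2.0-fold higher number from compound 1 to compound 2 (0.30 log units; within the scatter), with dimethylamino in place of hydrogen on an aromatic carbon. That step concerns the same aromatic ring and stays within the scatter. Among the compounds with values here, no measured compound carries a nitro group, so the series offers no direct reading of 3-nitrophenyl.

No step beyond the scatter is expected in this assay, and the direction remains weakly defined. The expected change is a 1.4-fold lower number from compound 2 to compound 3 (0.15 log units; within the scatter), which stays within the scatter. For compound 3 the estimated value is 30000 nM, with an expected range of 14000 nM to 65000 nM.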

Compound 3, concentration for total growth inhibition: 560 nM
For compound 3 the middle estimate is 54-fold (1.73 log units) above the measured one, outside the stated range (below it).
By their numbers in this assay, from the lowest: compound 3; then compounds 1 and 2 (each within the scatter of the next).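

In this assay the aryl group on the carbon with a double bond to nitrogen can move the read-out well beyond the scatter: there is a 75-fold lower number from compound 2 to compound 3 (1.88 log units; beyond the scatter) with 3-nitrophenyl in place of 4-(dimethylamino)phenyl, and a 37-fold lower number from compound 1 to compound 3 (1.57 log units; beyond the scatter) with nitro in place of hydrogen on an aromatic carbon. The earlier pair, compound 1 and compound 2, could not be separated, so the dimethylamino change gave no sign that this part of the structure mattered, whereas compound 3 now stands apart from both by large steps. No measurement here accounts for the size of these steps, and the reason for them stays unexplained.

Whether the step belongs to the nitro group in particular stays open, since no other group on this ring, such as a nitrile, a trifluoromethyl group or a carboxylic acid, appears among the compounds shown, and the nitro group appears on only one ring carbon. Also open, on these data alone, is whether the same step would hold with a different chain, since all three compounds share one core.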